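The compounds below may be only part of what the source reports. "The series", "measured", "known", "first", "only" and "open" are said of these compounds alone.

Of the compounds shown here, two that share a core have been measured so far in a functional assay on MCF7 cells (Homo sapiens) for cytotoxicity, read by colorimetric assay and MTT assay; on this read-out higher numbers stand for weaker inhibition and lower numbers for stronger inhibition. Compound 1 `COc1cccc2cc(-c3ccccc3)c(O)nc12` gives 10000 nM. Compound 2 `COc1ccc2cc(-c3ccccc3)c(O)nc2c1`, which differs in where its methoxy group sits, gives 10000 nM. That leaves compound 2 level with compound 1, within the usual scatter of repeated measurements.

Compound 3 `COc1cc(OC)c2cc(-c3ccccc3)c(O)nc2c1` comes from compound 2 through a single change: methoxy in place of hydrogen on an aromatic carbon. In words, this is methoxy in place of hydrogen on an aromatic carbon. Within the data shown here, no measured pair shows what adding such a group does, so the expectation rests mainly on compound 2 at 10000 nM. In this assay, no step beyond the scatter is expected, and any small shift would more likely be towards stronger inhibition. The expected change is a 1.3-fold lower number from compound 2 to compound 3 (0.10 log units; within the scatter). For compound 3 the estimated value is 8000 nM, with an expected range of 3000 nM to 20000 nM.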

Compound 3, half-maximal inhibitory concentration: 10000 nM
Compound 3: middle estimate off by 1.3-fold (0.10 log units), on the low side; the range from low to high includes it.
By their numbers in this assay, from the lowest: compounds 1, 2 and 3 (each within the scatter of the next).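

Placing a methoxy group on an aromatic carbon of compound 2, ortho to a fused ring and meta to the methoxy group already there, gives no change at the digits printed from compound 2 to compound 3 (within the scatter) in this assay. Among these compounds, compounds 1 and 2 differ only in where one methoxy group sits, so this is the first step that shows what adding a group does, and here a second methoxy group brings no measurable difference at this position. No measurement here gives a reason for this result.

Going by these compounds, whether an amine, a carboxylic acid or a longer chain such as butoxy at this same position would behave like methoxy remains open. Also open, on these data alone, is whether any other change to the shared core would give a lower number in this assay at all.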